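The source may hold more compounds than are shown below. What is called first, only, known or untested is meant among the compounds shown, and "the series" means these compounds.

Measured compounds:
compound 1, `CC1(C)C[C@H](O)C[C@](C)(CNc2ccccc2)C1`, 37000 nM
compound 2, `CC1(C)C[C@H](O)C[C@](C)(CNc2ccccc2Cl)C1`, 6900 nM
compound 3, `CC1(C)C[C@H](O)C[C@](C)(CNc2cccc(C(F)(F)F)c2)C1`, 7800 nM

In an ADME assay on MDCK cells (Canis lupus familiaris) for cytotoxicity, read by MTT assay, with a stated time of 3 days (a lower number here means that less compound is tolerated, a higher number that more compound is tolerated), compound 1 gives 37000 nM, while compound 2 gives 6900 nM and compound 3 gives 7800 nM. Compound 2 is related to compound 1 by chloro in place of hydrogen on an aromatic carbon, which gave a 5.4-fold lower number from compound 1 to compound 2 (0.73 log units; beyond the scatter). Compound 3 is related to compound 1 by trifluoromethyl in place of hydrogen on an aromatic carbon, which gave a 4.7-fold lower number from compound 1 to compound 3 (0.68 log units; beyond the scatter). Compound 4, `CC1(C)C[C@H](O)C[C@](C)(CNc2ccc(Cl)c(C(F)(F)F)c2)C1`, is related to compound 3 by chloro in place of hydrogen on an aromatic carbon; this is the same kind of change as that from compound 1 to compound 2, though here the place is ortho to a trifluoromethyl group and para to a large group, whereas before it was ortho to a large group. Because the earlier change gave a 5.4-fold lower number from compound 1 to compound 2 (0.73 log units; beyond the scatter), a step of roughly a 2.2-fold lower number from compound 3 to compound 4 (0.35 log units; beyond the scatter) is expected, though somewhat smaller. Compound 4 is therefore estimated at 3500 nM, between 1500 nM and 8000 nM.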

Compound 4, half-maximal cytotoxic concentration: 2800 nM
Compound 4: the middle estimate sits 1.3-fold (0.10 log units) above what was measured; low and high end bracket the measured number.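

In this assay, chloro in place of hydrogen on an aromatic carbon again lowered the number, giving a 2.8-fold lower number from compound 3 to compound 4 (0.44 log units; beyond the scatter). The step carried over from the core of compound 1 to the trifluoromethyl-bearing core of compound 3 in direction, and its size did not differ beyond the scatter: the same change on two cores in this assay, a 5.4-fold lower number (0.73 log units; beyond the scatter) from compound 1 to compound 2 and a 2.8-fold lower number (0.44 log units; beyond the scatter) from compound 3 to compound 4, 1.9-fold (0.28 log units) apart, within the scatter of two such steps. Within the data shown here, these are only two pairs, with the chloro at a different place in each, so they do not show that the step would hold at other places or on other cores.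

The compounds shown leave open whether a methoxy or nitrile group in place of the chloro would move the number the same way. They also leave open whether chloro would do so on a core carrying a carboxylic acid in place of the hydroxyl.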